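Furan-2-yl in Place of 4-Chlorophenyl on the Shared Core

The source may report more compounds than this note shows. Statements on the series, on what has been measured and on what is new or still open speak of the compounds shown alone.

For the measured compounds named here, compound 2 `CC1(C)CC(=O)C2=C(C1)NC(c1ccccc1)=CC2c1ccc(Cl)cc1` is the only entry with a number in an assay on isolated protein for inhibition of glucose-6-phosphatase catalytic subunit 1 (Homo sapiens), read by inositol phosphate accumulation, with a stated time of 30 min, tested at 100 uM; on this read-out lower numbers stand for less inhibition and higher numbers for more inhibition at the one concentration tested (going by the name of the read-out); in this assay compound 2 gives 7.16%. Compound 1 `CCOC(=O)C1(O)CC(c2ccc(F)cc2)C2=C(CC(C)(C)CC2=O)O1` is reported in this assay as "not active" (no number reported), without a number. Going by the values given here, no step between two measured compounds is available. Compound 3 `CC1(C)CC(=O)C2=C(C1)NC(c1ccccc1)=CC2c1ccco1` differs from compound 2 by furan-2-yl in place of 4-chlorophenyl on a saturated ring carbon. Among the compounds with values here, with no measured step to lean on, the expected step of a number 1.2 percentage points lower from compound 2 to compound 3 (within the scatter) is small, within the scatter, in neither direction. Compound 3 is expected to give 6% in this assay, with a range of 0% to 18%.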

Compound 3, a percentage reported as inhibition, at one concentration (the size of the read-out at that concentration, not a potency): 11.4%
For compound 3 the middle estimate is 5.4 percentage points below the measured one; low and high end bracket the measured number.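

For the compounds shown here, the step of a number 4.2 percentage points higher from compound 2 to compound 3 (within the scatter) in this assay is the first one available at this saturated ring carbon. It shows that exchanging a six-membered aromatic ring of carbon only for a five-membered aromatic ring with 1 hetero atom does not separate the two compounds beyond the scatter. No measured property bears on this step.

As far as these compounds go, whether an amine or a carboxylic acid at this ring carbon would give a step beyond the scatter remains open. So does the effect of replacing the phenyl group on the shared core.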